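This account rests on a few compounds, and the source may have more. Where it says the series, first, only, none or still open, it means among the compounds named here.

Compound 1 `CCCCCCCC/C=C\CCCCCCCC(=O)OC[C@H](C)OP(=O)(O)OC[C@H](N)C(=O)O` gives 11.3% in an assay on HEK293 cells for agonist activity at putative P2Y purinoceptor 10 (Mus musculus), with a stated time of 1 h; on this read-out lower numbers stand for smaller maximal responses and higher numbers for larger maximal responses. Compound 2 `CCCCCCCC/C=C\CCCCCCCC(=O)OC[C@@H](COC)OP(=O)(O)OC[C@H](N)C(=O)O` is reported in this assay as "not active" (no number reported), so compound 2 stands without a number, and only compound 1 carries a measured maximal response in the set. Compound 3 `CCCCCCCC/C=C\CCCCCCCC(=O)OC[C@H](COC)OP(=O)(O)OC[C@H](N)C(=O)O` follows from compound 2 by the two compounds have the same atoms and bonds; at least one stereo element is drawn with a configuration in one of them and without one in the other: 1 of 4 stereo elements differ; a stereocentre at a saturated chain carbon is drawn R in compound 2 and S in compound 3. Within the data shown here, no measured step covers such a change here, so any expectation rests on the low response of compound 1 and the inactivity of compound 2. For compound 3 a small maximal response is expected in this assay, estimated at 10% with a range from 0% to 25%, with a fair chance that only inactivity is reported.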

Compound 3, largest response reached (Emax), in percent of the reference or control that the assay uses: "not active" (no number reported)
No number was reported for compound 3; the estimate stays without a comparison.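

Compound 2 and compound 3 are both reported only as "not active" in this assay, and no step can be read between them. Going by these compounds, whether the configuration at the saturated chain carbon affects the maximal response in this assay stays open.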